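Replacing pyrrolidin-1-yl with benzyl(methyl)amino on a carbonyl carbon

This account rests on a few compounds, and the source may have more. Where it says the series, first, only, none or still open, it means among the compounds named here.

Two compounds measured so far in an ADME assay on BE(2)-C cells (Homo sapiens) for cytotoxicity, read by MTT assay, with a stated time of 20 h; on this read-out higher numbers stand for lower toxicity in this test and lower numbers for higher toxicity in this test

Compound 1 `CC(NC(=O)C1CCN(C(=O)c2cc3ccccc3n2Cc2ccc(Cl)cc2)CC1)c1ccncc1` gives 90100 nM
Compound 2 `O=C(c1cc2ccccc2n1Cc1ccc(Cl)cc1)N1CCC(C(=O)N2CCCC2)CC1` gives 65600 nM

Of the two numbers in hand, that of compound 2 lies within the scatter of compound 1. Compound 3 `CN(Cc1ccccc1)C(=O)C1CCN(C(=O)c2cc3ccccc3n2Cc2ccc(Cl)cc2)CC1` carries benzyl(methyl)amino in place of pyrrolidin-1-yl on a carbonyl carbon and is still unmeasured. Among the measured compounds shown here, the only measured step on this carbonyl carbon is a 1.4-fold lower number from compound 1 to compound 2 (0.14 log units; within the scatter) so no step beyond the scatter is expected. In this assay the expected step is a 1.1-fold higher number from compound 2 to compound 3 (0.03 log units; within the scatter) and no more. Compound 3 is estimated at 70000 nM with 30000 nM to 150000 nM as its expected range.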

Compound 3, half-maximal cytotoxic concentration: 87000 nM
Estimate against measurement, compound 3: 1.2-fold (0.09 log units) below, within the range that was stated.
By their numbers in this assay, from the lowest: compounds 2, 3 and 1 (each within the scatter of the next).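

In this assay, benzyl(methyl)amino on the carbonyl carbon brings a six-membered aromatic ring of carbon only, yet both new steps stay within the scatter, with a 1.3-fold higher number from compound 2 to compound 3 (0.12 log units; within the scatter) and a 1.0-fold lower number from compound 1 to compound 3 (0.02 log units; within the scatter). Across compounds 1, 2 and 3, this position has now carried three different groups without a step beyond the scatter. Nothing measured here explains this. From the compounds shown here alone, it remains open whether a carboxylic acid or a simple primary amide at this carbonyl carbon would also stay within the scatter.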